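Swapping Bromine for Methoxy on a Weakly Cytotoxic Core

The compounds below may be only part of what the source reports. "The series", "measured", "known", "first", "only" and "open" are said of these compounds alone.

Three compounds share one core and differ only on a single phenyl ring. In a functional assay on HT-1080 cells (Homo sapiens) for cytotoxicity, read by MTT assay, with a stated time of 24 h (on this read-out higher numbers stand for weaker inhibition and lower numbers for stronger inhibition), compound 1 `Clc1ccc(-c2nnc(C(NCc3ccccc3)c3ccc[nH]3)o2)cc1` gives 41000 nM, compound 2 `Clc1ccc(-c2nnc(C(NCc3ccccc3)c3ccc[nH]3)o2)cc1Cl` gives 15200 nM, and compound 3 `Brc1ccc(-c2nnc(C(NCc3ccccc3)c3ccc[nH]3)o2)cc1` gives 70600 nM. Compound 3 shows the highest number of the three: a 1.7-fold higher number from compound 1 to compound 3 (0.24 log units; within the scatter), whereas a 4.6-fold higher number from compound 2 to compound 3 (0.67 log units; beyond the scatter). Compound 4 `COc1ccc(-c2nnc(C(NCc3ccccc3)c3ccc[nH]3)o2)cc1` carries methoxy in place of bromo on an aromatic carbon. Going by the values given here, no measured step replaces a halogen with methoxy, so there is no direct precedent; the one exchange of that group, chloro for bromo, stayed within the scatter. A step in this assay of about a 1.2-fold lower number from compound 3 to compound 4 (0.07 log units; within the scatter) is therefore expected, with little confidence in either direction. Compound 4 is estimated at 60000 nM, within 20000 nM to 180000 nM.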

Compound 4, half-maximal inhibitory concentration: 170000 nM
The estimate for compound 4 lay 2.8-fold (0.45 log units) below the measured number; low and high end bracket the measured number.
By their numbers in this assay, from the lowest: compound 2; then compounds 1 and 3 (each within the scatter of the next); then compound 4.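

The two halogens, chloro and bromo, could not be told apart at this position on the phenyl ring, but methoxy separates from both in this assay: a 2.4-fold higher number from compound 3 to compound 4 (0.38 log units; beyond the scatter) and a 4.1-fold higher number from compound 1 to compound 4 (0.62 log units; beyond the scatter). The widest gap among these compounds is an 11-fold higher number from compound 2 to compound 4 (1.05 log units; beyond the scatter), so compound 4 has the highest number of the four and compound 2 the lowest. Nothing available explains these steps.

On these data alone, whether an amine or a carboxylic acid at this position would give a lower or a higher number stays open. So does whether a longer chain such as ethoxy would follow methoxy.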